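The source may hold more compounds than are shown below. What is called first, only, known or untested is meant among the compounds shown, and "the series" means these compounds.

Measured so far in a functional assay on L1210 cells (Mus musculus), with a stated time of 12 days; on this read-out lower numbers stand for lower potency and higher numbers for higher potency (the scale is a negative logarithm):
compound 1, `CC1=C(N2CC2)C(=O)C(C2CCCCC2)=C(N2CC2)C1=O`: 5.39
compound 2, `CC1=C(N2CC2)C(=O)C(N2CC2)=C(N2CC2)C1=O`: 6.21

Compound 2 stands highest of the two numbers; its nearest neighbour is compound 1, a step lower and beyond the scatter. Compound 3 `COC(CO)C1=C(N2CC2)C(=O)C(C)=C(N2CC2)C1=O` has not been measured. Its change from compound 2: 2-hydroxy-1-methoxyethyl in place of aziridin-1-yl on a double-bonded ring carbon. Among the compounds with values here, one measured step bears on it indirectly: a number 0.82 log units higher from compound 1 to compound 2 (beyond the scatter) showed aziridin-1-yl outdoing cyclohexyl at a double-bonded ring carbon. Compound 3 gives up aziridin-1-yl for a group without a ring, so a downward step in this assay is expected, a number 0.81 log units lower from compound 2 to compound 3 (beyond the scatter). Compound 3 is estimated at 5.4, range 4.8 to 6.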

Compound 3, logarithm of the reciprocal of the active concentration, log(1/C): 5.75
Compound 3: middle estimate off by 0.35 log units, on the low side; low and high end bracket the measured number.
By their numbers in this assay, from the lowest: compound 1; then compound 3; then compound 2.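

At the double-bonded ring carbon, the open chain 2-hydroxy-1-methoxyethyl falls between the two ringed groups in this assay: replacing aziridin-1-yl gives a number 0.46 log units lower from compound 2 to compound 3 (beyond the scatter) and replacing cyclohexyl gives a number 0.36 log units higher from compound 1 to compound 3 (beyond the scatter). The presence of a ring therefore does not set the order at this position, and a group with no ring can outdo cyclohexyl. No measurement at hand accounts for this order.

Open, going by these compounds, is where a plain propyl chain or a dimethylamino group would fall at this carbon. Also open, on these data alone, is whether 2-methoxyethyl, without the hydroxyl, would keep the level of compound 3.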